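The compounds below may be only part of what the source reports. "The series", "measured", "known", "first", "only" and "open" are said of these compounds alone.

Compound 3 `CC(C)(N)C(=O)N[C@H](COCc1ccccc1)c1nnnn1CCC#N` is one of three members of a series built on a shared core that differs only in the group carried on the aromatic nitrogen. In a functional assay on H4 cells for agonist activity at growth hormone secretagogue receptor type 1 (Homo sapiens), read by FLIPR (a higher number here means that more compound is needed for the effect, a lower number that less compound is needed), compound 3 gives 30 nM. Its neighbours are compound 2 `CC(C)(N)C(=O)N[C@H](COCc1ccccc1)c1nnnn1CC#N`, which gives 29 nM, and compound 1 `COC(=O)C(c1ccccc1)n1nnnc1[C@@H](COCc1ccccc1)NC(=O)C(C)(C)N`, which gives 20 nM; the steps of a 1.0-fold higher number from compound 2 to compound 3 (0.01 log units; within the scatter) and a 1.5-fold higher number from compound 1 to compound 3 (0.18 log units; within the scatter) both lie within the scatter, so the three numbers cannot be told apart.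

Compound 4 `CC(C)(N)C(=O)N[C@H](COCc1ccccc1)c1nnnn1CCC(=O)NCCCc1ccccc1` has not yet been measured. It differs from compound 3 by (3-phenylpropyl)carbamoyl in place of cyano on a saturated chain carbon, two bonds along the chain from an aromatic nitrogen. Among the compounds with values here, the steps that bear on this position are a 1.5-fold higher number from compound 1 to compound 2 (0.16 log units; within the scatter), a 1.5-fold higher number from compound 1 to compound 3 (0.18 log units; within the scatter) and a 1.0-fold higher number from compound 2 to compound 3 (0.01 log units; within the scatter), each within the scatter, though none of them introduces a group of this size. On that basis the step of a 1.2-fold higher number from compound 3 to compound 4 (0.07 log units; within the scatter) is expected to stay within the scatter. For compound 4 in this assay a value of 35 nM is estimated, with a range from 12 nM to 110 nM.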

Compound 4, half-maximal effective concentration: 59 nM
For compound 4 the middle estimate is 1.7-fold (0.23 log units) below the measured one; low and high end bracket the measured number.
By their numbers in this assay, from the lowest: compounds 1, 2, 3 and 4 (each within the scatter of the next, the first and the last beyond it).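

In this assay the exchange gives a 2.0-fold higher number from compound 3 to compound 4 (0.29 log units; within the scatter) although the entering (3-phenylpropyl)carbamoyl has 12 heavy atoms and a six-membered aromatic ring, where the leaving cyano has 2 heavy atoms and no ring. Within the data shown here, the earlier steps at this position involved no group of this size, so this is the first sign that a group this large, with its amide hydrogen and carbonyl, can sit on the saturated chain carbon, two bonds along the chain from an aromatic nitrogen, without a step beyond the scatter. No measurement available here offers an explanation for this result.

The compounds shown do not separate the contribution of the carbamoyl from that of the 3-phenylpropyl part. They also leave open how a carboxylic acid, an amine or a longer chain would fare at this position.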